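Lengthening the Ring Substituent on the Fused Core of Compound 1

This account rests on a few compounds, and the source may have more. Where it says the series, first, only, none or still open, it means among the compounds named here.

Compound 1 `O=C(O)c1cc(-c2cccc(COc3ccc4c(=O)n(C5CC5)sc4c3)c2)ccc1Cl` gives 70.6% in an assay on HEK293 cells for positive allosteric modulation of metabotropic glutamate receptor 2 (Rattus norvegicus), read by thallium flux; a higher number here means a larger maximal response, a lower number a smaller maximal response.
Compound 2 `O=C(O)c1cc(-c2cccc(-c3ccc4c(c3)CN(C3CCCC3)C4=O)c2)ccc1Cl` gives 85.8% in this assay.

Compound 1 stands lowest of the two measured compounds; compound 2 lies higher by a margin beyond the usual scatter. Compound 3 `O=C(O)c1cc(-c2cccc(COc3ccc4c(=O)n(CC5CC5)sc4c3)c2)ccc1Cl` has not been measured. It differs from compound 1 by cyclopropylmethyl in place of cyclopropyl on an aromatic nitrogen. Among the measured compounds shown here, no measured pair shows this change, so the numbers give no direction for it. For compound 3 a step within the scatter is expected, a number 1.4 percentage points higher from compound 1 to compound 3 (within the scatter), in either direction. Compound 3 is estimated at 72%, between 55% and 90%.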

Compound 3, largest response reached (reported as percent of maximum), in percent of the reference or control that the assay uses: 38.4%
Compound 3: the middle estimate sits 33.6 percentage points above what was measured; the whole stated range lies above it.
By their numbers in this assay, from the lowest: compound 3; then compound 1; then compound 2.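

In this assay, cyclopropylmethyl in place of cyclopropyl on the aromatic nitrogen next to the ring sulfur gives a number 32.2 percentage points lower from compound 1 to compound 3 (beyond the scatter) and so shows that the maximal response depends on the group at this position. The three-membered ring is present on both sides of the change, which takes the group from 3 to 4 heavy atoms. Nothing available explains the drop.

As far as these compounds go, this rests on a single pair, so it remains open how a methyl, an isopropyl or a longer chain such as cyclopropylethyl would fare here.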